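Exocyclic double bond variant of compound 1: stability notes

The source may hold more compounds than are shown below. What is called first, only, known or untested is meant among the compounds shown, and "the series" means these compounds.

Measured so far:
compound 1, `CC(C)C(c1ccc(-c2ccc3cccc(F)c3c2)[nH]c1=O)C1C(=O)NC(=O)N1C`: 0.263 h
compound 2, `CC(C)[C@@H](c1ccc(-c2ccc3cccc(F)c3c2)[nH]c1=O)[C@@H]1OC(=O)NC1=O`: 1.27 h

In an ADME assay on microsomes from liver (Rattus norvegicus) for metabolic stability (a lower number here means that the compound disappears faster, a higher number that the compound lasts longer), compound 1 gives 0.263 h, the lowest of the two numbers in hand. Compound 2 gives 1.27 h, a higher value, and the gap between the two is beyond the scatter. Among the compounds with values here, no single-point step can be drawn from this pair, as the two compounds differ in more than one place.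

Compound 3, `CC(C)C(/C=C1/C(=O)NC(=O)N1C)c1ccc(-c2ccc3cccc(F)c3c2)[nH]c1=O`, is not yet measured. It differs from compound 1 in one place: a group of 9 heavy atoms (5 carbon, 2 nitrogen, 2 oxygen; one five-membered non-aromatic ring with 2 hetero atoms) in place of a group of 8 heavy atoms (4 carbon, 2 nitrogen, 2 oxygen; one five-membered non-aromatic ring with 2 hetero atoms), on a saturated chain carbon bound to an aromatic carbon and a saturated chain carbon. The 3-methyl-2,5-dioxoimidazolidin-4-yl group leaves and a group with 3 double bonds outside aromatic rings enters, on the saturated chain carbon bound to an aromatic carbon and a saturated chain carbon.

Within the data shown here, nothing in hand shows how a change of this kind moves this assay; the only comparison available, compound 1 against compound 2, involves a different five-membered ring. A step of a 1.3-fold higher number from compound 1 to compound 3 (0.12 log units; within the scatter) is expected, small and within the scatter. For compound 3 the estimate in this assay is 0.35 h, with a range from 0.15 h to 0.9 h.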

Compound 3, half-life: 1.08 h
Estimate against measurement, compound 3: 3.1-fold (0.49 log units) below; measured number outside the range, above it.
By their numbers in this assay, from the lowest: compound 1; then compounds 3 and 2 (each within the scatter of the next).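

In this assay, within the data shown here, the exchange of the 3-methyl-2,5-dioxoimidazolidin-4-yl group for the group of 9 heavy atoms with 3 double bonds outside aromatic rings gives a 4.1-fold higher number from compound 1 to compound 3 (0.61 log units; beyond the scatter) and so provides the first readable step at this place, on a saturated chain carbon bound to an aromatic carbon and a saturated chain carbon. The two groups have the same counts of hydrogen-bond donors and acceptors, no net charge and one five-membered non-aromatic ring with 2 hetero atoms, so a step beyond the scatter is possible here with all of these counts unchanged. No measurement on hand bears on what lies behind the step.

As far as these compounds go, with a single pair, the added carbon and the added double bond outside aromatic rings cannot be separated, and whether the step would carry over to another core remains open. From the compounds shown here alone, how this assay would respond to a carboxylic acid or an amine in place of the ring group, on the same saturated chain carbon, also remains open.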